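Methoxy on the propoxy chain of compound 3

The compounds below may be only part of what the source reports. "The series", "measured", "known", "first", "only" and "open" are said of these compounds alone.

In a physicochemical assay for lipophilicity, read by HPLC, in phosphate buffer, measured as octanol-water partition, at pH 7.4, tested at 100 uM (a lower number here means a more polar compound, a higher number a more lipophilic compound), compound 1 (`CCCOc1cc(C)c(-c2cccc(CNc3ccc(OCC(=O)O)c(F)c3)c2)c(C)c1`) reads 3.59 and compound 2 (`COCCOc1cc(C)c(-c2cccc(CNc3ccc(OCC(=O)O)c(F)c3)c2)c(C)c1`) reads 2.47 on the same scale. Compound 3 (`CCCOc1ccc(-c2cccc(CNc3ccc(OCC(=O)O)c(F)c3)c2)c(C)c1`) reads 3.37 on that scale, which puts it within the scatter of compound 1 and well above compound 2.

The next step leads to compound 4 (`COCCOc1ccc(-c2cccc(CNc3ccc(OCC(=O)O)c(F)c3)c2)c(C)c1`), where the propoxy chain of compound 3 becomes 2-methoxyethoxy (methoxy in place of methyl on a saturated chain carbon, two bonds along the chain from an oxygen on an aromatic ring). This is methoxy in place of methyl on a saturated chain carbon, two bonds along the chain from an oxygen on an aromatic ring.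

The same exchange has a single measured precedent, which gave a number 1.12 log units lower from compound 1 to compound 2 (beyond the scatter) in this assay on the other background. The two backgrounds differ by hydrogen in place of methyl on an aromatic carbon, and that change gave a number 0.22 log units lower from compound 1 to compound 3 (within the scatter) on its own. Going by the values given here, no measured pair yet shows whether the chain exchange keeps its size without that methyl, so one precedent carries the whole expectation.

A large downward step of similar size is expected, and the step estimated here is a number 1.12 log units lower from compound 3 to compound 4 (beyond the scatter) in this assay for this exchange. The estimate for compound 4 is 2.25 with an expected range from 1.9 to 2.6 on this scale.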

Compound 4, distribution coefficient: 2.23
Estimate against measurement, compound 4: 0.02 log units above; the range from low to high includes it.
By their numbers in this assay, from the lowest: compounds 4 and 2 (each within the scatter of the next); then compounds 3 and 1 (each within the scatter of the next).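

In this assay the exchange of propoxy to 2-methoxyethoxy now stands on two backgrounds, with a number 1.14 log units lower from compound 3 to compound 4 (beyond the scatter) and, on the background carrying the extra methyl, a number 1.12 log units lower from compound 1 to compound 2 (beyond the scatter) as the earlier instance. The large downward step therefore no longer rests on a single pair, and across these four compounds its size holds with or without that methyl on the aromatic carbon. The second change can now also be read twice: hydrogen in place of methyl on an aromatic carbon gives a number 0.24 log units lower from compound 2 to compound 4 (within the scatter) on the 2-methoxyethoxy background and a number 0.22 log units lower from compound 1 to compound 3 (within the scatter) on the propoxy background, so it stays within the scatter on both.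

The compounds shown cover only this one exchange at this place, so it remains open how the number would respond to a longer ether chain, a terminal hydroxyl or an amine on the same chain, or to an ether oxygen set further along it. Nothing among the supporting data accounts for the size of the step.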